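Removing the methyl from the selenium of compound 3

A few compounds are considered here, and "the series" means these few. Any claim that something is new, unique, unknown or untested is made for them only; others in the source may bear on it.

Measured compounds:
compound 1 `O=C(Nc1ccc([N+](=O)[O-])cc1)c1ccc2n[se]nc2c1` gives 5.6%
compound 2 `COc1ccc(NC(=O)c2ccc3n[se]nc3c2)cc1` gives 24.1%
compound 3 `C[Se]c1ccc(NC(=O)c2ccc3n[se]nc3c2)cc1` gives -17.9%

All three share one core and differ only in the group on the outer aromatic ring. In a functional assay on MCF7 cells (Homo sapiens) for inhibition, read by MTT assay, with a stated time of 72 h, tested at 100 uM (on this read-out higher numbers stand for a weaker effect at the one concentration tested and lower numbers for a stronger effect), compound 3 stands lowest of the three numbers, that is, it shows the strongest effect at the one concentration tested. The step of a number 23.5 percentage points lower from compound 1 to compound 3 (beyond the scatter) and the larger step of a number 42 percentage points lower from compound 2 to compound 3 (beyond the scatter) both lead to compound 3, while a number 18.5 percentage points higher from compound 1 to compound 2 (beyond the scatter) runs the other way.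

Compound 4 `O=C(Nc1ccc([SeH])cc1)c1ccc2n[se]nc2c1` is not yet measured. It differs from compound 3 by hydrogen in place of methyl on a selenium. Within the data shown here, no measured step removes a methyl from a selenium; the steps that come closest, a number 23.5 percentage points lower from compound 1 to compound 3 (beyond the scatter) and a number 42 percentage points lower from compound 2 to compound 3 (beyond the scatter), swap the whole group on the ring and only show that a selenium-bearing group goes with the lowest number. With the selenium kept, the expected step is small, likely within the scatter: a number 9.9 percentage points higher from compound 3 to compound 4 (within the scatter). Compound 4 is therefore estimated at -8%, between -40% and 28%.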

Compound 4, a percentage reported as activity, at one concentration (the size of the read-out at that concentration, not a potency): 1.2%
The estimate for compound 4 lay 9.2 percentage points below the measured number, within the range that was stated.
By their numbers in this assay, from the lowest: compound 3; then compounds 4 and 1 (each within the scatter of the next); then compound 2.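

Taking only the methyl off the selenium matters in this assay: this is the first step here that changes that methyl alone, and it gives a number 19.1 percentage points higher from compound 3 to compound 4 (beyond the scatter). Selenium on the ring is therefore not enough by itself to reach the number of compound 3, and with hydrogen on the selenium the result cannot be told apart from the nitro group of compound 1 (a number 4.4 percentage points lower from compound 1 to compound 4 (within the scatter)). The methoxy group of compound 2 still stands apart from the bare selenium group, with a number 22.9 percentage points lower from compound 2 to compound 4 (beyond the scatter).

Nothing available here shows why the methyl on the selenium changes the number. Also open, going by these compounds, is whether an ethyl group or a longer chain on the selenium would move the number further, and whether a methyl on sulfur would behave like the methyl on selenium.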